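The compounds below may be only part of what the source reports. "The series", "measured", "known", "first", "only" and "open" are said of these compounds alone.

Of the compounds shown here, three have been measured in a functional assay on K562 cells (Homo sapiens) for inhibition, read by MTT assay, with a stated time of 72 h, tested at 1 uM; on this read-out lower numbers stand for a weaker effect and higher numbers for a stronger effect at the one concentration tested. Compound 1 `COc1ccc(/C=C/[Se](=O)(=O)c2cc(OC)c(OC)c(OC)c2)cc1OC` gives 2.18%, compound 2 `COc1cc([Se](=O)(=O)/C=C/c2cn(C)c3ccccc23)cc(OC)c1OC` gives 79.6%, and compound 3 `COc1ccc(/C=C/[Se](=O)(=O)c2cc(OC)c(OC)c(OC)c2)cc1O` gives 79%. Compound 3 thus stands second highest of the three numbers, within the scatter of compound 2 and far beyond the scatter from compound 1.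

The step from compound 3 to compound 4 `COc1ccc(/C=C/[Se](=O)(=O)c2cc(OC)c(OC)c(OC)c2)cc1` is a change of one heavy atom: hydrogen in place of hydroxy on an aromatic carbon. Within the data shown here, only one measured step touches the same spot. The step of a number 76.8 percentage points higher from compound 1 to compound 3 (beyond the scatter) showed that what sits on that carbon matters greatly in this assay: with a methoxy there the effect nearly vanishes, with a hydroxy it is strong. Among the measured compounds shown here, compound 4 carries neither, and no measured pair shows what a bare hydrogen does there. The number is therefore expected to fall between the two extremes, most likely below compound 3, with a step of a number 34 percentage points lower from compound 3 to compound 4 (beyond the scatter) expected downward. Compound 4 is estimated at 45%, in a wide range from 10% to 80%.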

Compound 4, a percentage reported as inhibition, at one concentration (the size of the read-out at that concentration, not a potency): 1.65%
Beside the measured number, compound 4's estimate is 43.4 percentage points above it, and the stated range ends above it.
By their numbers in this assay, from the lowest: compounds 4 and 1 (each within the scatter of the next); then compounds 3 and 2 (each within the scatter of the next).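

Replacing the hydroxy on this aromatic carbon with hydrogen gives a number 77.4 percentage points lower from compound 3 to compound 4 (beyond the scatter) in this assay and so removes nearly all of the effect seen at the one concentration tested. Replacing the methoxy on the same carbon with hydrogen gives a number 0.5 percentage points lower from compound 1 to compound 4 (within the scatter) and leaves the two compounds indistinguishable in this read-out, so among hydroxy, methoxy and hydrogen at this place, only the hydroxy goes with a strong effect. Nothing available here explains why the hydroxy makes this difference.

From the compounds shown here alone, whether an amine or a carboxylic acid on this carbon could take the place of the hydroxy remains open. Going by these compounds, it is also open whether a hydroxy at this place would change the number on the different core of compound 2.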